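Alkyl to benzyl in a series held at a limit

A few compounds are considered here, and "the series" means these few. Any claim that something is new, unique, unknown or untested is made for them only; others in the source may bear on it.

Measured in a functional assay on HT-29 cells (Homo sapiens) for antiproliferative activity, read by MTT assay, with a stated time of 72 h; a lower number here means a stronger inhibitor, a higher number a weaker inhibitor:
compound 1 `COc1cc(-c2nccn2C)cc(OC)c1OC`: > 100000 nM
compound 2 `CCn1ccnc1-c1cc(OC)c(OC)c(OC)c1`: > 100000 nM
compound 3 `COc1cc(-c2nccn2C(C)C)cc(OC)c1OC`: > 100000 nM

Each entry is a limit of the assay and not a number. Compound 2 gives only the limit > 100000 nM. It therefore has no numerical position in the series, and the same holds for the other two compounds, as the limit of > 100000 nM in this assay, at which 3 of the 3 values shown sit, shows.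

The open case is compound 4 `COc1cc(-c2nccn2Cc2ccccc2)cc(OC)c1OC`, which differs from compound 2 as follows: phenyl in place of methyl on a saturated chain carbon bound to an aromatic nitrogen. Cut one bond further out, the same difference reads ethyl to benzyl.

The measured steps that bear on this change all concern the group on that nitrogen: a step that the two limits leave unreadable from compound 1 to compound 2, a step that the two limits leave unreadable from compound 2 to compound 3 and a step that the two limits leave unreadable from compound 1 to compound 3. Both ends of each step are limits, and none has a readable size. Going by the values given here, no measured compound carries a ring in this place.

Because of the limit of > 100000 nM in this assay, at which 3 of the 3 values shown sit, a further limit is the expected result in this assay. The estimated at least 1.1-fold lower number from compound 2 to compound 4 (0.04 log units; that floor lies within the scatter) is small, and no firm direction is expected. For compound 4 the estimate is 90000 nM, with an expected range of 25000 nM to 200000 nM.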

Compound 4, half-maximal inhibitory concentration: > 100000 nM
Compound 4 was reported as a limit; the forecaster's own chance of this, stated with the estimate: 70%; at least 1.1-fold (0.04 log units) between middle value and limit.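

In this assay compound 4 gives > 100000 nM, a limit of the assay and not a number. Going by these compounds alone, no step from compound 1, compound 2 or compound 3 to compound 4 can be read, because both ends of each are limits: the limit of > 100000 nM in this assay, at which 4 of the 4 values shown sit. The compounds shown leave open whether any group on the aromatic nitrogen gives a measurable value.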